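The source may hold more compounds than are shown below. What is called first, only, known or untested is meant among the compounds shown, and "the series" means these compounds.

Measured compounds in a physicochemical assay for lipophilicity, using the shake flask method, in phosphate buffer, measured as octanol-water partition, with a stated time of 5 h; a lower number here means a more polar compound, a higher number a more lipophilic compound:
compound 1 `O=C(CN1CCN(c2cc3c(cc2F)c(=O)c(C(=O)O)cn3C2CC2)CC1)Nc1ccc(C(=O)/C=C/c2ccccc2)cc1` gives 1.29
compound 2 `O=C(CN1CCN(c2cc3c(cc2F)c(=O)c(C(=O)O)cn3C2CC2)CC1)Nc1ccc(C(=O)/C=C/c2ccccc2Cl)cc1` gives 1.29

Compound 2 stands level with compound 1 at the digits shown; the step of no change at the digits printed from compound 1 to compound 2 (within the scatter) lies within the scatter, so the two partition coefficients cannot be told apart. Compound 3 `O=C(CN1CCN(c2cc3c(cc2F)c(=O)c(C(=O)O)cn3C2CC2)CC1)Nc1ccc(C(=O)/C=C/c2cccc(Cl)c2)cc1` is not yet measured in this assay. It differs from compound 2 in one place: 3-chlorophenyl in place of 2-chlorophenyl on a double-bonded chain carbon bound to a double-bonded chain carbon. Compound 2 and compound 3 have the same atoms, joined differently.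

The only measured step, no change at the digits printed from compound 1 to compound 2 (within the scatter), concerns chloro in place of hydrogen on an aromatic carbon and gave no change at the digits shown. For the measured compounds named here, no measured pair shows a chlorophenyl replaced by a differently substituted chlorophenyl, so the bearing of the measured data on the step from compound 2 to compound 3 is indirect. Going by the values given here, with the same atoms retained and the one measured step being flat, the step of no change at the digits printed from compound 2 to compound 3 (within the scatter) is expected to fall within the scatter, with no direction favoured. Compound 3 is therefore estimated at 1.29 in this assay, with a range from 0.95 to 1.65.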

Compound 3, partition coefficient: 0.302
Estimate against measurement, compound 3: 0.99 log units above; the whole stated range lies above it.
By their numbers in this assay, from the lowest: compound 3; then compounds 1 and 2 (each within the scatter of the next).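

In this assay, the exchange of 2-chlorophenyl for 3-chlorophenyl on the double-bonded chain carbon gives a number 0.99 log units lower from compound 2 to compound 3 (beyond the scatter), so a change that leaves the atoms the same, only joined differently, can move this read-out beyond the scatter. Chloro in place of hydrogen on an aromatic carbon also no longer reads as a silent change: it gives no change at the digits printed from compound 1 to compound 2 (within the scatter) but also a number 0.99 log units lower from compound 1 to compound 3 (beyond the scatter), and across these two steps its outcome depends on which chlorophenyl results, with compound 2 going against any rule drawn from compound 3 alone. Nothing available accounts for the gap between the 2-chlorophenyl and 3-chlorophenyl compounds.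

Still open, as far as these compounds go, is whether the lower number belongs to chloro specifically or would recur with 3-bromophenyl or 3-methylphenyl on the same chain carbon. From the compounds shown here alone, it is equally open where 4-chlorophenyl would fall relative to compound 2 and compound 3, which would show whether the 2-chlorophenyl or the 3-chlorophenyl compound is the exception.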